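N-Methylation of the Piperazine in a Quinolone Series

The compounds below may be only part of what the source reports. "The series", "measured", "known", "first", "only" and "open" are said of these compounds alone.

Compound 1 `CCn1cc(-c2nc3ccc(Cl)cc3[nH]2)c(=O)c2cc(F)c(N3CCNCC3)cc21`: 2800 nM
Compound 2 `CCn1cc(-c2nc3ccc(N)cc3[nH]2)c(=O)c2cc(F)c(N3CCNCC3)cc21`: 10000 nM

Compound 2 gives the highest number of the two in a functional assay on THP-1 cells (Homo sapiens) for cytotoxicity, read by sulforhodamine B assay, with a stated time of 48 h; on this read-out higher numbers stand for weaker inhibition and lower numbers for stronger inhibition; compound 1 stands nearest, with a 3.6-fold higher number from compound 1 to compound 2 (0.55 log units; beyond the scatter) between them. Compound 3 `CCn1cc(-c2nc3ccc(N)cc3[nH]2)c(=O)c2cc(F)c(N3CCN(C)CC3)cc21` differs from compound 2 by methyl in place of hydrogen on an amine nitrogen in a ring. For the measured compounds named here, no measured step in this assay involves a change on the ring nitrogen, so the only measured step, from chloro to amino on an aromatic carbon, does not bear on this one. With nothing to point either way, no step beyond the scatter is expected: compound 3 is estimated at 10000 nM, within 3500 nM to 30000 nM, meaning no change at the digits printed from compound 2 to compound 3 (within the scatter).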

Compound 3, half-maximal inhibitory concentration: > 10000 nM
Compound 3 gave a limit, no number; the forecaster's own chance of this, stated with the estimate: 20%; the middle value lies on the limit itself.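

In this assay compound 3 gives > 10000 nM, which is a limit and not a number. Replacing piperazin-1-yl with 4-methylpiperazin-1-yl is the only change on this ring nitrogen shown, and the result is a number no lower from compound 2 to compound 3 (the limit leaves the size open), so this methyl brings no sign of stronger inhibition, though the size of the step cannot be read. The read-out stops at the edge of the assay's range: the limit of > 10000 nM in this assay, at which 1 of the 3 values shown sits.

Going by these compounds, whether the same methyl would behave alike with chloro in place of amino, as in compound 1, stays open. So does the effect of an ethyl or acetyl group on this nitrogen.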